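The source may report more compounds than this note shows. Statements on the series, on what has been measured and on what is new or still open speak of the compounds shown alone.

Compound 3 `NC1=N[C@@H](c2ccccc2)CO1` shares its core with compound 1 `Cc1ccccc1[C@H]1COC(N)=N1` and compound 2 `CN(C[C@H]1COC(N)=N1)c1cccc(Cl)c1`. In a functional assay on HEK293 cells for agonist activity at trace amine-associated receptor 1 (Homo sapiens), read by cAMP accumulation, with a stated time of 30 min (a higher number here means that more compound is needed for the effect, a lower number that less compound is needed), compound 3 gives 67 nM; compound 1 gives 67 nM, and compound 2 gives 27 nM. Compound 3 thus stands level with compound 1 at the top of the three numbers, and the gap to compound 2 is the only one beyond the scatter. Within the data shown here, the one measured step on the aromatic ring, no change at the digits printed from compound 1 to compound 3 (within the scatter), shows that a substituent change on this ring left this assay unchanged.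

Compound 4 `NC1=N[C@@H](c2cccc(F)c2)CO1` differs from compound 3 by fluoro in place of hydrogen on an aromatic carbon. Among the measured compounds shown here, no measured step introduces a halogen on this ring with the core otherwise unchanged; compound 2 carries a chloro on its ring, but its linker differs as well, so its value cannot be separated into parts. For the measured compounds named here, the nearest step, the one from compound 1 to compound 3, is small, so for compound 4 a step of about a 1.3-fold lower number from compound 3 to compound 4 (0.13 log units; within the scatter) in this assay is expected, and compound 4 is estimated at 50 nM, with a range of 20 nM to 150 nM.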

Compound 4, half-maximal effective concentration: 490 nM
Beside the measured number, compound 4's estimate is 9.8-fold (0.99 log units) below it; measured number outside the range, above it.
By their numbers in this assay, from the lowest: compound 2; then compounds 1 and 3 (each within the scatter of the next); then compound 4.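

Fluoro in place of hydrogen on an aromatic carbon, meta to a group of 6 heavy atoms, gives a 7.3-fold higher number from compound 3 to compound 4 (0.86 log units; beyond the scatter) in this assay and is the first step on this ring to lie beyond the scatter. Among these compounds, the only earlier step on the ring, no change at the digits printed from compound 1 to compound 3 (within the scatter), had suggested that the ring was indifferent to substitution, but this single added fluorine atom shows that it is not, with compound 1 and compound 3 remaining the case against any general rule. Nothing available here bears on why this step raises the number.

As far as these compounds go, whether the rise belongs to fluoro itself or to this ring carbon remains open. Chloro, methyl, methoxy or a nitrile on the same carbon, and fluoro on another carbon of the ring, would separate the two.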